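A Second Chloro on the Core of Compound 1

This account rests on a few compounds, and the source may have more. Where it says the series, first, only, none or still open, it means among the compounds named here.

Compound 1 `ClCc1cccc(Cn2cnc3ncnc(Cl)c32)c1` stands second highest among three numbers in a functional assay on NCI/ADR-RES cells (Homo sapiens) for cytotoxicity, read by sulforhodamine B assay, with a stated time of 48 h (a higher number here means a weaker inhibitor of growth, a lower number a stronger inhibitor of growth), where compound 1 gives 2750 nM. Compound 2 `ClCc1ccccc1Cn1cnc2ncnc(Cl)c21` gives 2080 nM, a number within the scatter of that of compound 1. Compound 3 `ClCc1ccc(Cn2cnc3c(Cl)nc(Cl)nc32)cc1`, which carries two chloro groups on its core and a differently substituted benzyl group, gives 16600 nM, beyond the scatter above compound 1. Compound 4 `ClCc1cccc(Cn2cnc3nc(Cl)nc(Cl)c32)c1` differs from compound 1 by chloro in place of hydrogen on an aromatic carbon. Among the measured compounds shown here, no measured pair isolates this change, since compound 3 differs from compound 1 in two places. A modest weakening is expected, a 2.0-fold higher number from compound 1 to compound 4 (0.30 log units; within the scatter), because compound 3 as the only dichloro core measured gives 16600 nM. Compound 4 is estimated at 5500 nM, within 1800 nM to 17000 nM.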

Compound 4, concentration for 50% growth inhibition: 1540 nM
The estimate for compound 4 lay 3.6-fold (0.55 log units) above the measured number; measured number outside the range, below it.
By their numbers in this assay, from the lowest: compounds 4, 2 and 1 (each within the scatter of the next); then compound 3.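

Among the compounds shown here, this pair is the first to isolate the change: in this assay, chloro in place of hydrogen on an aromatic carbon, between two ring nitrogen atoms, gives a 1.8-fold lower number from compound 1 to compound 4 (0.25 log units; within the scatter). The position therefore accepts a chloro group with a step that stays within the scatter, so on this benzyl group the second chloro on the core does not separate the two compounds. Nothing measured here gives a reason for this result. From the compounds shown here alone, whether an amine, a methoxy group or a longer chain at this position would also stay within the scatter of compound 1 remains open.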